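A few compounds are considered here, and "the series" means these few. Any claim that something is new, unique, unknown or untested is made for them only; others in the source may bear on it.

In an ADME assay on Raji cells (Homo sapiens) for cytotoxicity, with a stated time of 72 h (on this read-out lower numbers stand for an effect already at smaller amounts and higher numbers for an effect only at larger amounts of compound), the two measured compounds stand as follows.

Compound 1 `CSc1ccc(NC(=O)Nc2cc(C)nc3ccccc23)cc1`: > 25000 nM, a limit of the assay rather than a number.
Compound 2 `Cc1cc(NC(=O)Nc2ccc(SC(F)(F)F)cc2)c2ccccc2n1`: 10000 nM.

Within the data shown here, compound 2 gives the only number in this assay; compound 1 sits at the limit of > 25000 nM in this assay, at which 1 of the 2 values shown sits. Among the measured compounds shown here, the one measured step, an at least 2.5-fold lower number from compound 1 to compound 2 (0.39 log units; beyond the scatter), is therefore at least modest and runs toward a lower number.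

Compound 3 `CCc1ccc(NC(=O)Nc2cc(C)nc3ccccc23)cc1` differs from compound 2 by ethyl in place of (trifluoromethyl)sulfanyl on an aromatic carbon. The measured step bears on it only loosely: it concerns trifluoromethyl in place of methyl on a sulfur, whereas here the whole (trifluoromethyl)sulfanyl group leaves and ethyl enters. Since the group that gave compound 2 its lower number is removed, the number is expected to move back upward in this assay, possibly to a limit again. Compound 3 is estimated at 20000 nM, within 8000 nM to 50000 nM. This is expected to be a 2.0-fold higher number from compound 2 to compound 3 (0.30 log units; within the scatter).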

Compound 3, half-maximal effective concentration: > 25000 nM
Compound 3: no number, only a limit; the forecaster's own chance of this, stated with the estimate: 50%; middle value at least 1.2-fold (0.09 log units) away from the limit.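

Taking out the whole (trifluoromethyl)sulfanyl group at this place, on an aromatic carbon para to a large group, and putting ethyl there gives in this assay an at least 2.5-fold higher number from compound 2 to compound 3 (0.39 log units; beyond the scatter), so the lower number of compound 2 does not carry over to this ethyl group. Compound 1 and compound 3, with methylsulfanyl and ethyl at this place, both end at the same limit of the assay rather than at a number: the limit of > 25000 nM in this assay, at which 2 of the 3 values shown sit. The step between these two cannot be read.

On these data alone, how far compound 1 and compound 3 lie beyond that limit stays open, and so does any order between methylsulfanyl and ethyl. Also open, as far as these compounds go, is whether an amine, a carboxylic acid or a longer chain at this place would give a number within the range of the assay.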